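Methoxy to methylsulfanyl on the shared core of compound 1

The source may hold more compounds than are shown below. What is called first, only, known or untested is meant among the compounds shown, and "the series" means these compounds.

Measured compounds:
compound 1, `COc1ncnc2c1c(-c1ccoc1)cn2[C@@H]1O[C@H](CO)[C@@H](O)[C@H]1O`, 28800 nM
compound 2, `COc1nc(N)nc2c1c(-c1ccoc1)cn2[C@@H]1O[C@H](CO)[C@@H](O)[C@H]1O`, > 100000 nM

In an ADME assay on BJ cells (Homo sapiens), read by MTT assay, with a stated time of 72 h (on this read-out lower numbers stand for stronger inhibition and higher numbers for weaker inhibition), compound 1 gives 28800 nM. Compound 1 holds the only number shown; the other value is a limit. For compound 2 the value > 100000 nM is a limit of the assay, not a number, as shown by the limit of > 100000 nM in this assay, at which 1 of the 2 values shown sits. Within the data shown here, the one measured step, an at least 3.4-fold higher number from compound 1 to compound 2 (0.54 log units; beyond the scatter), concerns amino in place of hydrogen on an aromatic carbon and does not touch the group changed here.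

Compound 3, `CSc1ncnc2c1c(-c1ccoc1)cn2[C@@H]1O[C@H](CO)[C@@H](O)[C@H]1O`, is not yet measured. It differs from compound 1 by methylsulfanyl in place of methoxy on an aromatic carbon, on an aromatic carbon of a six-membered aromatic ring with two nitrogen, next to the ring nitrogen. Among the measured compounds shown here, no measured step bears on a methoxy to methylsulfanyl exchange, so nothing argues for a shift beyond the scatter in either direction.

Compound 3 is therefore expected to sit close to compound 1, an estimated 1.1-fold lower number from compound 1 to compound 3 (0.04 log units; within the scatter). The estimate for compound 3 is 26000 nM, within 8000 nM to 85000 nM.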

Compound 3, half-maximal inhibitory concentration: 98800 nM
Compound 3: the middle estimate sits 3.8-fold (0.58 log units) below what was measured; measured number above the stated range.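

In this assay, the place on the shared core that carries methoxy responds to the exchange of one atom: methylsulfanyl in place of methoxy gives a 3.4-fold higher number from compound 1 to compound 3 (0.54 log units; beyond the scatter). Among these compounds, the earlier step concerned amino at another place, so this is the first reading at this position, and it shows weaker inhibition with a group that matches methoxy in the heavy atom, donor and acceptor counts and differs from it in having sulfur for oxygen. The number for compound 3 is still a true number, but little room remains between it and the limit of the read-out: the limit of > 100000 nM in this assay, at which 1 of the 3 values shown sits.

With only these two groups at this position, one step cannot show whether sulfur itself drives the change or whether most departures from methoxy would do the same; an amine, a chlorine atom or a longer chain such as ethoxy at this place would separate the two readings. Whether the exchange behaves alike on the amino-bearing core of compound 2 also stays open, and the furan-3-yl-type substituent and the sugar are constant throughout the compounds shown.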